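This account rests on a few compounds, and the source may have more. Where it says the series, first, only, none or still open, it means among the compounds named here.

Three compounds have so far been tested in a functional assay on CEM-DNR-bulk cells (Homo sapiens), read by MTT assay, with a stated time of 72 h; a higher number here means a weaker inhibitor, a lower number a stronger inhibitor:

Compound 1 `CN(C)c1ncnc2c1c(-c1cc3ccccc3o1)cn2[C@@H]1O[C@H](CO)[C@@H](O)[C@H]1O`: > 20000 nM
Compound 2 `O=c1[nH]cnc2c1c(-c1cccs1)cn2[C@@H]1O[C@H](CO)[C@@H](O)[C@H]1O`: > 20000 nM
Compound 3 `C#Cc1cn([C@@H]2O[C@H](CO)[C@@H](O)[C@H]2O)c2ncnc(N(C)C)c12`: 240 nM

Compound 1 stands at the limit of this assay, so its value is a limit and not a number. Compound 2 also sits at the limit. In this set, two of the three values are limits (the limit of > 20000 nM in this assay, at which 2 of the 3 values shown sit). For the measured compounds named here, compound 3 is the only one with a measured number, and the single step among measured compounds, an at least 83-fold lower number from compound 1 to compound 3 (1.92 log units; beyond the scatter), comes from ethynyl in place of 1-benzofuran-2-yl on an aromatic carbon.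

Compound 4 `CNc1ncnc2c1c(-c1cc3ccccc3o1)cn2[C@@H]1O[C@H](CO)[C@@H](O)[C@H]1O` is not yet measured. It differs from compound 1 by hydrogen in place of methyl on a nitrogen on an aromatic ring, which, read one bond further out, is dimethylamino to methylamino. Going by the values given here, none of the measured steps touches that nitrogen; the only measured step changes a different part of the core, so it gives no direct guide for this change. With compound 1 at the limit and a small change at a place not yet probed, the expectation is no step beyond the scatter. Compound 4 is therefore expected to show a number no higher from compound 1 to compound 4 (the limit leaves the size open). For compound 4 the estimate is 20000 nM, with a range from 5000 nM to 60000 nM, and the result is most likely to be a limit again.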

Compound 4, half-maximal inhibitory concentration: > 20000 nM
Compound 4: a limit, no number; the forecaster's own chance of this, stated with the estimate: 75%; the middle value lies on the limit itself.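

Compound 1 and compound 4 both stand at the limit of the assay, and no number separates them, so no step between them can be read: the limit of > 20000 nM in this assay, at which 3 of the 4 values shown sit.

The compounds shown leave open whether methylamino in place of dimethylamino changes the result in this assay at all, either on this shared core or on one that gives a measured number, such as compound 3.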